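This account rests on a few compounds, and the source may have more. Where it says the series, first, only, none or still open, it means among the compounds named here.

Measured compounds:
- compound 1, `COc1ccc2c(=O)c(/C=C/C(=O)Nc3ccccc3)coc2c1`, in a functional assay on Huh-7 cells (Homo sapiens) for inhibition, read by MTT assay, with a stated time of 48 h (a higher number here means a weaker inhibitor, a lower number a stronger inhibitor), compound 1 gives 9050 nM
- compound 2, `Cc1ccccc1NC(=O)/C=C/c1coc2cc(O)ccc2c1=O`, in this assay compound 2 gives 11100 nM

Compound 2 carries the higher of the two numbers, but its nearest neighbour is compound 1, and the gap between the two values lies within the usual scatter of repeated measurements, so the two compounds are treated here as indistinguishable in this assay. Compound 1 is the anilide with the methoxy-bearing core; compound 2 is the 2-methylphenyl anilide with the hydroxy-bearing core. Among the compounds with values here, no pair of measured compounds differs in a single place, so no measured step is available for this series.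

The next compound, compound 3, `O=C(/C=C/c1coc2cc(O)ccc2c1=O)Nc1ccccc1`, is derived from compound 2 by the change (hydrogen in place of methyl on an aromatic carbon). It keeps the hydroxy-bearing core of compound 2 and the plain anilide of compound 1. Both measured compounds sit within the scatter of one another, and nothing measured separates the effect of the methyl from that of the core substituent. The step expected for this change is therefore small, with no direction beyond the scatter: compound 3 is expected to give 10000 nM in this assay, within the range 4000 nM to 25000 nM, corresponding to an expected step of a 1.1-fold lower number from compound 2 to compound 3 (0.05 log units; within the scatter).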

Compound 3, half-maximal inhibitory concentration: 3880 nM
For compound 3 the middle estimate is 2.6-fold (0.41 log units) above the measured one, outside the stated range (below it).
By their numbers in this assay, from the lowest: compound 3; then compounds 1 and 2 (each within the scatter of the next).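

In this assay, hydrogen in place of methyl on an aromatic carbon ortho to a large group, 2-methylphenyl to phenyl, gives a 2.9-fold lower number from compound 2 to compound 3 (0.46 log units; beyond the scatter), so this position on the anilide responds to a change of a single carbon. At the other place, hydrogen in place of methyl on an oxygen on an aromatic ring gives a 2.3-fold lower number from compound 1 to compound 3 (0.37 log units; beyond the scatter), and the two earlier compounds, which differ in both places at once, could not show either step separately. No measurement available here accounts for either step.

Still open, on these data alone, is whether the methyl itself is what counts at this carbon, or whether a chlorine, a methoxy or an ethyl group there would give a similar step, and whether the hydroxy on the core can be exchanged for an amine or a longer alkoxy chain without a step in the other direction. Also open, as far as these compounds go, is whether the two steps add up, which would need the 2-methylphenyl anilide on the methoxy-bearing core of compound 1 for a complete set of four.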